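The source may hold more compounds than are shown below. What is called first, only, known or untested is meant among the compounds shown, and "the series" means these compounds.

In a functional assay on PBMC cells (Homo sapiens) for inhibition, read by thymidine incorporation, with a stated time of 72 h (a higher number here means a weaker inhibitor, a lower number a stronger inhibitor), compound 1 `CC1(C)CC(=O)C(C(=S)SCCO)=C(Nc2ccc(Cl)cc2)C1` gives 21 ug/mL. Compound 2 `CC1(C)CC(=O)C(C(=S)SCc2ccccc2)=C(Nc2ccc(Br)cc2)C1` in this assay reaches only > 50 ug/mL, which is a limit of the assay and not a number. Compound 2 thus stands at the limit of > 50 ug/mL in this assay, at which 1 of the 2 values shown sits. Compound 3 `CC1(C)CC(=O)C(C(=S)SCCO)=C(Nc2ccc(Br)cc2)C1` differs from compound 2 by hydroxymethyl in place of phenyl on a saturated chain carbon bound to a sulfur. Compound 3 carries the same 2-hydroxyethyl chain as compound 1, and compound 1 gives 21 ug/mL in this assay. Compound 3 is therefore expected near 22 ug/mL, in the range 8 ug/mL to 50 ug/mL. The expected step of an at least 2.2-fold lower number from compound 2 to compound 3 (0.35 log units; beyond the scatter) runs toward stronger inhibition, beyond the usual scatter.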

Compound 3, half-maximal inhibitory concentration: 8.3 ug/mL
For compound 3 the middle estimate is 2.7-fold (0.42 log units) above the measured one; the range from low to high includes it.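

In this assay, hydroxymethyl in place of phenyl on a saturated chain carbon bound to a sulfur gives an at least 6.0-fold lower number from compound 2 to compound 3 (0.77 log units; beyond the scatter), so this position responds to the change, with the size known only as a bound. Compound 2 stands at a limit of the assay and not at a number: the limit of > 50 ug/mL in this assay, at which 1 of the 3 values shown sits. For the compounds shown here, with the 2-hydroxyethyl chain kept, bromo in place of chloro on an aromatic carbon gives a 2.5-fold lower number from compound 1 to compound 3 (0.40 log units; beyond the scatter), the first readable step at that halogen.

The compounds shown leave open how an amine or a carboxylic acid in place of the hydroxyl would read. Going by these compounds, a longer chain ending in hydroxyl also remains open.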